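Methyl added to the carboxymethyl arm of compound 3

A few compounds are considered here, and "the series" means these few. Any claim that something is new, unique, unknown or untested is made for them only; others in the source may bear on it.

Three compounds of this series have numbers in a functional assay on CHO cells for antagonist activity at sphingosine 1-phosphate receptor 2 (Homo sapiens), read by GTPgammaS binding; a higher number here means a weaker inhibitor, a lower number a stronger inhibitor. Compound 1 `CCOc1cc2[nH]c(Cc3nn(CC(=O)N4CCOCC4)c(=O)c4ccccc34)nc2cc1Cl` gives 22 nM. Compound 2 `O=C(Cc1nn(CC(=O)N2CCOCC2)c(=O)c2ccccc12)Nc1ccc(OC(F)(F)F)c(Cl)c1` gives 103 nM. Compound 3 `O=C(O)Cn1nc(Cn2cc3cc(OCC4CC4)c(Cl)cc3n2)c2ccccc2c1=O` gives 53 nM, the second highest of the three; its gap to compound 2 lies within the scatter, while compound 1 sits at a lower number, beyond the scatter.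

Compound 4 `C[C@H](C(=O)O)n1nc(Cn2cc3cc(OCC4CC4)c(Cl)cc3n2)c2ccccc2c1=O` is not yet measured. It differs from compound 3 by methyl in place of hydrogen on a saturated chain carbon bound to an aromatic nitrogen and a carbonyl carbon. Among the compounds with values here, no measured pair shows this change, so the series gives no direction for it. The expected step is small, a 1.1-fold lower number from compound 3 to compound 4 (0.03 log units; within the scatter), and not beyond the scatter. Compound 4 is therefore estimated at 50 nM, with a range of 20 nM to 130 nM.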

Compound 4, half-maximal inhibitory concentration in the sphingosine 1-phosphate receptor 2 assay: 15 nM
For compound 4 the middle estimate is 3.3-fold (0.52 log units) above the measured one; the measured number lies below the stated range.
By their numbers in the sphingosine 1-phosphate receptor 2 assay, from the lowest: compounds 4 and 1 (each within the scatter of the next); then compounds 3 and 2 (each within the scatter of the next).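

Within the data shown here, at the saturated chain carbon bound to an aromatic nitrogen and a carbonyl carbon, methyl in place of hydrogen gives in the sphingosine 1-phosphate receptor 2 assay a 3.5-fold lower number from compound 3 to compound 4 (0.55 log units; beyond the scatter) as the first single-place step, with compound 3 at 53 nM and compound 4 at 15 nM, so this position responds to substitution. In a physicochemical assay for lipophilicity, at pH 7.4 (on this read-out higher numbers stand for higher lipophilicity and lower numbers for lower lipophilicity), the same change gives a number 0.20 log units higher from compound 3 to compound 4 (within the scatter) and does not separate the two compounds on that read-out, with compound 3 at 2.79 and compound 4 at 2.99. Nothing available explains the step.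

As far as these compounds go, the opposite configuration at this carbon remains open, as do a second methyl, an ethyl or a longer chain there. From the compounds shown here alone, whether the methyl carries over to the morpholine amide arm of compound 1 also remains open.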